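This account rests on a few compounds, and the source may have more. Where it says the series, first, only, none or still open, it means among the compounds named here.

Compound 1 `O=C(c1cccc(Cl)c1)c1ccn(-c2ccc3c(c2)B(O)OC3)c1` gives > 10 ug/mL in an ADME assay on L929 cells (Mus musculus) for cytotoxicity, read by resazurin assay, with a stated time of 72 h (on this read-out higher numbers stand for weaker inhibition and lower numbers for stronger inhibition), which is a limit of the assay and not a number. Compound 2 `Cc1ccc(C(=O)c2ccn(-c3ccc4c(c3)B(O)OC4)c2)cc1` gives > 10 ug/mL in this assay, again a limit rather than a number. Compound 3 `O=C(c1ccn(-c2ccc3c(c2)B(O)OC3)c1)c1cccs1` gives > 10 ug/mL in this assay, also a limit.

Compound 3 therefore stands at the limit of > 10 ug/mL in this assay, at which 3 of the 3 values shown sit. The steps that lead to it, a step that the two limits leave unreadable from compound 1 to compound 3 and a step that the two limits leave unreadable from compound 2 to compound 3, cannot be read in size; the same holds for a step that the two limits leave unreadable from compound 1 to compound 2. The unmeasured compound 4 `Cc1ccsc1C(=O)c1ccn(-c2ccc3c(c2)B(O)OC3)c1` differs from compound 3 by methyl in place of hydrogen on an aromatic carbon. Within the data shown here, none of the measured steps yields a readable size, so no step beyond the scatter is expected in this assay from this change, and the most likely outcome is that compound 4 again reaches only the limit. Compound 4 is accordingly estimated at 20 ug/mL, with a range from 8 ug/mL to 60 ug/mL. That estimate means an expected step that the limit leaves unreadable from compound 3 to compound 4, within the scatter.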

Compound 4, half-maximal inhibitory concentration: > 10 ug/mL
Compound 4: a limit, no number (the forecaster's own chance of this, stated with the estimate: 85%); the middle value does not contradict the limit.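

In this assay compound 4 gives a limit and not a number, as do compounds 1, 2 and 3, so none of the steps from those compounds to compound 4 can be read in size: the limit of > 10 ug/mL in this assay, at which 4 of the 4 values shown sit.

The compounds shown leave open whether methyl in place of hydrogen on an aromatic carbon, or any other change among them, alters the result in this assay at all.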